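Butyl in place of 4-methylphenyl on a triple-bonded carbon

The compounds below may be only part of what the source reports. "The series", "measured", "known", "first", "only" and "open" are said of these compounds alone.

Measured in a functional assay on MCF7 cells (Homo sapiens) for antiproliferative activity, read by MTT assay, with a stated time of 3 days; a higher number here means a weaker inhibitor, a lower number a stronger inhibitor:
- Compound 1 `Cc1ccc(C#Cc2cn(C/C=C\CN3C(=O)c4ccccc4C3=O)c(=O)[nH]c2=O)cc1` gives > 100000 nM (a limit)
- Compound 2 `CCCCCCC#Cc1cn(C/C=C/CN2C(=O)c3ccccc3C2=O)c(=O)[nH]c1=O` gives 24000 nM as a number
- Compound 3 `CCCCCC#Cc1cn(C/C=C/CN2C(=O)c3ccccc3C2=O)c(=O)[nH]c1=O` gives 44000 nM as a number

On this assay compound 1 stands at > 100000 nM which is a limit and not a number. Compound 4 `CCCCC#Cc1cn(C/C=C\CN2C(=O)c3ccccc3C2=O)c(=O)[nH]c1=O` has butyl in place of 4-methylphenyl on a triple-bonded carbon, and the counted change is butyl in place of 4-methylphenyl on a triple-bonded carbon in full. For the measured compounds named here, the only measured step, a 1.8-fold higher number from compound 2 to compound 3 (0.26 log units; within the scatter) on a saturated chain, lies within the scatter and exchanges no 4-methylphenyl, so it bears only loosely. Compound 3 at 44000 nM shows that a chain-bearing compound can give a number, so a modest step toward a lower number is expected. For compound 4 a limit remains possible. The expected change is an at least 1.6-fold lower number from compound 1 to compound 4 (0.22 log units; that floor lies within the scatter) by this estimate. For compound 4 the estimated value is 60000 nM with an expected range from 25000 nM to 100000 nM in this read-out.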

Compound 4, half-maximal inhibitory concentration: 45000 nM
Compound 4: middle estimate off by 1.3-fold (0.12 log units), on the high side; measured number inside the range.
By their numbers in this assay, from the lowest: compounds 2, 3 and 4 (each within the scatter of the next). At a limit, above all of these: compound 1.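

In this assay, butyl in place of 4-methylphenyl on a triple-bonded carbon gives an at least 2.2-fold lower number from compound 1 to compound 4 (0.34 log units; beyond the scatter), the first step shown that lies beyond the scatter and the first to exchange an aromatic ring at this place for a chain. Only a floor for the size of this step is known, as compound 1 stands at a limit: the limit of > 100000 nM in this assay, at which 1 of the 4 values shown sits.

The compounds shown leave open how an unsubstituted phenyl, or an amine or a carboxylic acid at the end of the chain, would read at this place. They also leave the full size of the change open.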